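A Methoxy Group Added Beside Dimethylamino: Expected Solubility

The source may report more compounds than this note shows. Statements on the series, on what has been measured and on what is new or still open speak of the compounds shown alone.

Three measured compounds share one core. Compound 1 `O=C(CCCCCNc1c(Nc2ccccc2)c(=O)c1=O)NO` gives 2200000 nM in a physicochemical assay for solubility, with a stated time of 24 h, tested at 30 mg/mL; on this read-out higher numbers stand for higher solubility and lower numbers for lower solubility. Compound 2 `CN(C)c1ccc(Nc2c(NCCCCCC(=O)NO)c(=O)c2=O)cc1` gives 1400000 nM in this assay, and compound 3 `COc1ccc(Nc2c(NCCCCCC(=O)NO)c(=O)c2=O)cc1` gives 300000 nM. The step of a 7.3-fold lower number from compound 1 to compound 3 (0.87 log units; beyond the scatter) comes from the change (methoxy in place of hydrogen on an aromatic carbon), whereas the cores of compound 1 and compound 2 differ by dimethylamino in place of hydrogen on an aromatic carbon, a change that gave a 1.6-fold lower number from compound 1 to compound 2 (0.20 log units; within the scatter).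

The unmeasured compound 4 `COc1cc(Nc2c(NCCCCCC(=O)NO)c(=O)c2=O)ccc1N(C)C` differs from compound 2 by methoxy in place of hydrogen on an aromatic carbon. This is the same kind of change as before, not the same: here the methoxy sits ortho to a dimethylamino group and meta to a large group, not para to a large group. A step of about a 5.6-fold lower number from compound 2 to compound 4 (0.75 log units; beyond the scatter) is expected, resting on the earlier step from compound 1 to compound 3, which was a 7.3-fold lower number from compound 1 to compound 3 (0.87 log units; beyond the scatter), though the changed surroundings add uncertainty. Compound 4 is therefore estimated at 250000 nM, with a range from 80000 nM to 800000 nM.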

Compound 4, solubility: 2600000 nM
The estimate for compound 4 lay 10-fold (1.02 log units) below the measured number; the measured number lies above the stated range.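

The same kind of change, methoxy in place of hydrogen on an aromatic carbon, gave a 7.3-fold lower number from compound 1 to compound 3 (0.87 log units; beyond the scatter) in this assay, but a 1.9-fold higher number from compound 2 to compound 4 (0.27 log units; within the scatter), so the earlier step did not carry over to this core. Among the compounds shown here, these are only two pairs, and in compound 4 the methoxy sits ortho to a dimethylamino group and meta to a large group, so they do not show how the change behaves on other cores. Nothing shown explains why the two steps differ.

The compounds shown leave open what a methoxy group does when ortho to a different group, such as an amine. They also leave open what a carboxylic acid in that same place would give in this assay.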